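This account rests on a few compounds, and the source may have more. Where it says the series, first, only, none or still open, it means among the compounds named here.

Compound 1 `CC1CC=C(C(=O)N(c2cc(C#CC(C)(C)C)sc2C(=O)O)C(C)C)CC1` was examined in an ADME assay on MT4 cells (Homo sapiens) for cytotoxicity, with a stated time of 5 days; a lower number here means that less compound is tolerated, a higher number that more compound is tolerated. In this assay compound 1 gives > 20000 nM, which is a limit of the assay and not a number. Compound 2 `C[C@H]1CC[C@H](C(=O)N(c2cc(C#CC3(C(F)(F)F)CC3)sc2C(=O)O)[C@H]2CC[C@H](Oc3ccc(=O)[nH]n3)CC2)CC1` likewise gives > 20000 nM in this assay, again a limit. Both values sit on (the limit of > 20000 nM in this assay, at which 2 of the 2 values shown sit), so compound 1 stands no differently from the other compound shown. Compound 3 `CC(C)N(C(=O)C1CCCCC1)c1cc(C#CC(C)(C)C)sc1C(=O)O` is not yet measured; it differs from compound 1 in cyclohexyl in place of 4-methylcyclohex-1-en-1-yl on a carbonyl carbon. Because both known values sit at the limit of > 20000 nM in this assay, at which 2 of the 2 values shown sit, compound 3 is expected to show a number no higher from compound 1 to compound 3 (the limit leaves the size open), nothing beyond the scatter. Compound 3 is therefore estimated at 20000 nM, ranging from 10000 nM to 40000 nM.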

Compound 3, half-maximal cytotoxic concentration: > 20000 nM
Compound 3 was reported as a limit; the forecaster's own chance of this, stated with the estimate: 85%; the middle value lies on the limit itself.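

In this assay compound 3 gives > 20000 nM, a limit and not a number. No step can be read between compound 1 and compound 3, as both values are limits: the limit of > 20000 nM in this assay, at which 3 of the 3 values shown sit.

The compounds shown leave open whether they differ at all in this assay.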